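The source may hold more compounds than are shown below. What is called first, only, known or untested is meant among the compounds shown, and "the series" means these compounds.

Measured so far in a functional assay on HT-29 cells (Homo sapiens) for antiproliferative activity, read by sulforhodamine B assay, with a stated time of 48 h; on this read-out higher numbers stand for weaker inhibition and lower numbers for stronger inhibition:

Compound 1 `Cc1ccccc1OS(=O)(=O)c1ccc(N2CCN(C)C2=O)cc1` gives 4800 nM.
Compound 2 `COc1ccccc1OS(=O)(=O)c1ccc(N2CCN(C)C2=O)cc1` gives 26000 nM.
Compound 3 `Cc1ccc(OS(=O)(=O)c2ccc(N3CCN(C)C3=O)cc2)c(C)c1` gives 3000 nM.

Among these three numbers compound 1 holds the second highest; compound 3 sits close to it, and compound 2 sits well above it. Compound 4 `CN1CCN(c2ccc(S(=O)(=O)Oc3ccc(F)cc3)cc2)C1=O` has not been measured. It differs from compound 1 in the group on the oxygen that is bound to the sulfonyl sulfur: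

4-fluorophenyl in place of 2-methylphenyl on an oxygen

Among the measured compounds shown here, two measured steps concern this same oxygen-bound group. a 5.4-fold higher number from compound 1 to compound 2 (0.73 log units; beyond the scatter), where methoxy replaced methyl, pushed the number well up; an 8.7-fold lower number from compound 2 to compound 3 (0.94 log units; beyond the scatter) brought it back down; a 1.6-fold lower number from compound 1 to compound 3 (0.20 log units; within the scatter), adding a second methyl, stayed within the scatter. None of them put a fluorine in place of the methyl, so the direction for compound 4 in this assay is open; the steps show that changes to this group can move the number by a modest amount in either direction. Taking the methyl away while adding fluorine is expected to leave compound 4 roughly where compound 1 stands, with a wide range, at an estimated 6000 nM (from 2000 nM to 20000 nM), which would be an expected step of a 1.3-fold higher number from compound 1 to compound 4 (0.10 log units; within the scatter).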

Compound 4, half-maximal inhibitory concentration: > 100000 nM
Compound 4: no number, only a limit; the forecaster's own chance of this, stated with the estimate: 5%; middle value at least 16-fold (1.22 log units) away from the limit.
By their numbers in this assay, from the lowest: compounds 3 and 1 (each within the scatter of the next); then compound 2. At a limit, above all of these: compound 4.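

In this assay compound 4 gives > 100000 nM, which is a limit of the assay and not a number. Read against that limit, the group on the oxygen bound to the sulfonyl sulfur can shift the number much further than the earlier compounds showed: an at least 20-fold higher number from compound 1 to compound 4 (1.31 log units; beyond the scatter), an at least 33-fold higher number from compound 3 to compound 4 (1.52 log units; beyond the scatter), and an at least 3.8-fold higher number from compound 2 to compound 4 (0.58 log units; beyond the scatter). So 4-fluorophenyl stands apart from all three groups measured before it, and even compound 2, which held the highest number until now, stays clearly lower in this comparison.

This single change takes away the methyl and brings in the fluorine together, so the compounds shown cannot tell which of the two matters. Plain phenyl, 4-methylphenyl and 2-fluorophenyl on the same oxygen remain open, and any of them would help to separate the two parts of the change.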